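A few compounds are considered here, and "the series" means these few. Any claim that something is new, unique, unknown or untested is made for them only; others in the source may bear on it.

Three chalcones share one core and have been measured in a functional assay on PC-3 cells (Homo sapiens) for cytotoxicity, with a stated time of 48 h; a higher number here means a weaker inhibitor, a lower number a stronger inhibitor. Compound 1 `COc1cc(OC)c(C(=O)/C=C/c2ccc(Cl)cc2)c(OC)c1` gives 5800 nM there; compound 2 `COc1cccc(/C=C/C(=O)c2c(O)cc(OC)cc2OC)c1` gives 7300 nM; compound 3 `COc1cc(O)c(C(=O)/C=C/c2ccccc2SC)c(OC)c1` gives 8700 nM. Compound 1 has the lowest of the three numbers, but its gap to compound 2 and its gap to compound 3 both lie within the usual scatter, so no order among the three can be read from these values.

Compound 4 `COc1cc(OC)c(C(=O)/C=C/c2ccccc2)c(OC)c1` has not yet been measured in this assay. It differs from compound 1 in one place: hydrogen in place of chloro on an aromatic carbon. Cut one bond further out, the same difference reads 4-chlorophenyl to phenyl.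

Among the compounds with values here, no pair of measured compounds differing in a single place is available, so the size of such a step has to be expected rather than read off. Across this small series, removing a substituent from the ring bearing the double bond is expected to shift the number upward only slightly, as a step from compound 1 to compound 4 of about a 1.5-fold higher number from compound 1 to compound 4 (0.17 log units; within the scatter), which may not exceed the scatter. Compound 4 is therefore estimated at 8500 nM in this assay, with a range from 4000 nM to 18000 nM.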

Compound 4, half-maximal inhibitory concentration: 5100 nM
Beside the measured number, compound 4's estimate is 1.7-fold (0.22 log units) above it, within the range that was stated.
By their numbers in this assay, from the lowest: compounds 4, 1, 2 and 3 (each within the scatter of the next).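

In this assay the series now has its first change in a single place: hydrogen in place of chloro on an aromatic carbon, para to a large group, gives a 1.1-fold lower number from compound 1 to compound 4 (0.06 log units; within the scatter) and this step lies within the scatter. On the core of compound 1, the change from 4-chlorophenyl to phenyl therefore has no readable direction, and the chloro is not shown to be required for the cytotoxicity read-out at this level of activity. No measured evidence at hand bears on the size of this step.

Within the data shown here, whether an amine, a carboxylic acid or a longer chain such as butoxy at the same position would move the number beyond the scatter remains open, since chloro and hydrogen are the only two groups compared there. Compound 2 and compound 3 each differ from compound 4 in more than one place, so steps for hydroxy in place of methoxy on the other aromatic ring, or for moving a substituent around the ring bearing the double bond, cannot be read.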